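The compounds below may be only part of what the source reports. "The series", "measured", "known", "first", "only" and "open" are said of these compounds alone.

Working notes on the series.

Compound 1 `Cc1nc2cc(C[C@H](C)CN3C[C@@H]4CCCC[C@@H]4[C@H](C(=O)N4CCN(c5ccc(F)c(F)c5)CC4)C3)ccc2o1` gives 3.39 nM in an assay on isolated protein for binding affinity to somatostatin receptor type 3 (Homo sapiens) (a lower number here means tighter binding, a higher number weaker binding), and is the tightest binder of the three measured. Compound 2 `Cc1cn2cc(C[C@H](C)CN3C[C@@H]4CCCC[C@@H]4[C@H](C(=O)N4CCN(c5ccc(F)c(F)c5)CC4)C3)ccc2n1` gives 107 nM in this assay, and compound 3 `C[C@@H](Cc1ccc2ncnn2c1)CN1C[C@@H]2CCCC[C@@H]2[C@H](C(=O)N2CCN(c3ccc(F)c(F)c3)CC2)C1` gives 34.7 nM. Compound 3 thus stands second highest of the three numbers: a 10-fold higher number from compound 1 to compound 3 (1.01 log units; beyond the scatter), while a 3.1-fold lower number from compound 2 to compound 3 (0.49 log units; beyond the scatter).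

Compound 4 `CCOc1ccc(C[C@H](C)CN2C[C@@H]3CCCC[C@@H]3[C@H](C(=O)N3CCN(c4ccc(F)c(F)c4)CC3)C2)cn1` is not yet measured. The change from compound 3 is a group of 9 heavy atoms (7 carbon, 1 nitrogen, 1 oxygen; one six-membered aromatic ring with 1 hetero atom) in place of a group of 9 heavy atoms (6 carbon, 3 nitrogen; one five-membered aromatic ring with 3 hetero atoms, one six-membered aromatic ring with 1 hetero atom), on a saturated chain carbon, three bonds along the chain from an amine nitrogen in a ring; the 6-ethoxypyridin-3-yl that enters carries one six-membered ring only, where every measured compound carries a fused pair of rings. For the measured compounds named here, no measured step exchanges a fused pair for a single ring, so none bears on it directly. The steps that do touch this position, a 32-fold higher number from compound 1 to compound 2 (1.50 log units; beyond the scatter) and a 10-fold higher number from compound 1 to compound 3 (1.01 log units; beyond the scatter), show that exchanges here move this assay by large amounts in either direction. The expectation for compound 4 is therefore an uncertain one; a moderate step of a 1.7-fold lower number from compound 3 to compound 4 (0.24 log units; within the scatter) is estimated, with wide bounds. For compound 4 the estimate is 20 nM, between 4 nM and 100 nM.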

Compound 4, dissociation constant: 14.1 nM
Compound 4: middle estimate off by 1.4-fold (0.15 log units), on the high side; low and high end bracket the measured number.
By their numbers in this assay, from the lowest: compound 1; then compound 4; then compound 3; then compound 2.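

In this assay, a single six-membered ring at this position does not cost binding relative to two of the fused pairs, as 6-ethoxypyridin-3-yl gives lower numbers than both groups it is compared with here (a 2.5-fold lower number from compound 3 to compound 4 (0.39 log units; beyond the scatter); a 7.6-fold lower number from compound 2 to compound 4 (0.88 log units; beyond the scatter)). A fused pair is therefore not needed for a number in this range, although the 2-methyl-1,3-benzoxazol-5-yl of compound 1 still stays ahead (a 4.2-fold higher number from compound 1 to compound 4 (0.62 log units; beyond the scatter)). No data are at hand that would explain these differences.

For the compounds shown here, only one single-ring group stands, so it remains open how much of the number of compound 4 rests on the ethoxy group and how much on the pyridine ring itself. A methoxy group, a longer alkoxy chain or an amine in place of the ethoxy group on the same ring would separate these two parts.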